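This account rests on a few compounds, and the source may have more. Where it says the series, first, only, none or still open, it means among the compounds named here.

In this assay, an assay for inhibition of Fatty-acid amide hydrolase 1 (Rattus norvegicus) (a lower number here means a stronger inhibitor, a higher number a weaker inhibitor), compound 1 `N#Cc1cccc(-c2cnc(C(=O)CCc3ccc(-c4ccccc4)cc3)o2)n1` gives 2.9 nM. Within the data shown here, compound 2 `NC(=O)c1ccc(-c2cnc(CCCc3ccc(-c4ccccc4)cc3)o2)nc1` gives 30000 nM in this assay, the higher of the two numbers: its only neighbour, compound 1, sits far below it, and the gap between the two lies well beyond the scatter of repeated measurements. Compound 3 `O=C(O)c1ccc(-c2cnc(CCCc3ccc(-c4ccccc4)cc3)o2)nc1` is drawn from compound 2 by a single change, (hydroxy in place of amino on a carbonyl carbon), so that the carbamoyl group of compound 2 becomes a carboxy group, the pyridine ring carrying it otherwise untouched. Among the measured compounds shown here, no measured pair shows this exchange, so nothing here says how large a shift it brings. Because compound 2 already stands at 30000 nM, the step is expected to be modest, a 1.7-fold higher number from compound 2 to compound 3 (0.22 log units; within the scatter), in the direction of a weaker inhibitor. Compound 3 is therefore estimated at 50000 nM, within a range from 12000 nM to 200000 nM.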

Compound 3, inhibition constant: 20000 nM
Estimate against measurement, compound 3: 2.5-fold (0.40 log units) above, within the range that was stated.
By their numbers in this assay, from the lowest: compound 1; then compounds 3 and 2 (each within the scatter of the next).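

In this assay, among these compounds, the single exchange of hydroxy for amino on a carbonyl carbon, which turns 5-carbamoylpyridin-2-yl into 5-carboxypyridin-2-yl, gives a 1.5-fold lower number from compound 2 to compound 3 (0.18 log units; within the scatter), so this assay does not tell the two groups apart. The carboxy group of compound 3 leaves the number at 20000 nM, on the same level as compound 2 within the scatter. Nothing available gives a reason for this result.

Compound 1 differs from compound 2 and compound 3 in more than one place, so its far lower number cannot be assigned to any one change. On these data alone, whether a methyl ester or a hydroxymethyl group in place of the carboxy group would read differently stays open, as does whether the same exchange would read alike with a carbonyl in the chain, as in compound 1.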